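This account rests on a few compounds, and the source may have more. Where it says the series, first, only, none or still open, it means among the compounds named here.

Working notes on the series. Of the compounds shown here, two have numbers so far, compound 1 (`Cc1c2c(n3c1CCCNC[C@H](C)Nc1cc-3ccc1C(N)=O)CC(C)(C)CC2=O`) and compound 2 (`CC(=O)N1CCc2c(C)c3c(n2-c2ccc(C(N)=O)c(c2)N[C@@H](C)[C@H](C)C1)CC(C)(C)CC3=O`). In an in vitro ADME assay on microsomes (Homo sapiens) for metabolic stability (on this read-out lower numbers stand for a shorter-lived compound and higher numbers for a longer-lived compound), compound 1 gives 0.167 h and compound 2 gives 0.05 h as the lower of the two numbers, a gap beyond the usual scatter. Compound 2 therefore stands at the short-lived end of the little that is measured.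

The next entry is compound 3 (`CC[C@H](N)C(=O)N1CCc2c(C)c3c(n2-c2ccc(C(N)=O)c(c2)N[C@@H](C)[C@H](C)C1)CC(C)(C)CC3=O`), which remains unmeasured. Compared with compound 2, it has 1-aminopropyl in place of methyl on a carbonyl carbon whose other neighbour is an amide-type nitrogen in a ring. In other words, acetyl becomes (1-aminopropyl)carbonyl.

Within the data shown here, no measured pair shows a change of this kind, so the only guide is compound 2 at 0.05 h as the starting point. The expected change is small, a slight rise at most and within the scatter, and the estimate amounts to a step of a 1.2-fold higher number from compound 2 to compound 3 (0.08 log units; within the scatter) in this assay with its direction uncertain. For compound 3 the estimated half-life is 0.06 h with an expected range from 0.025 h to 0.15 h as the working figure.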

Compound 3, half-life: 0.417 h
For compound 3 the middle estimate is 7.0-fold (0.84 log units) below the measured one; measured number outside the range, above it.
By their numbers in this assay, from the lowest: compound 2; then compound 1; then compound 3.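

Among these compounds, the carbonyl carbon on the amide-type nitrogen in a ring proves to be a position that moves the half-life in this assay: 1-aminopropyl in place of methyl gives an 8.3-fold higher number from compound 2 to compound 3 (0.92 log units; beyond the scatter), the first step that can be read from a single change. The larger group, which brings 1 hydrogen-bond donor, 1 hydrogen-bond acceptor and 1 defined stereocentre, therefore comes with a longer half-life rather than a shorter one, although this rests on one pair only. Nothing on hand ties the step to any feature of the entering group, so it stands as an observation without an explanation.

The compounds shown do not separate the contribution of the amine from that of the carbon chain, or show whether the defined stereocentre matters. A plain propyl or a shorter aminomethyl on the same carbonyl carbon, or 1-aminopropyl with the opposite stereocentre, would be the direct comparisons with compound 3.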